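Furan-2-yl amide of the shared core: expected potency

This account rests on a few compounds, and the source may have more. Where it says the series, first, only, none or still open, it means among the compounds named here.

Among the measured compounds shown here, the three compounds measured so far share one core and differ only in the group on the carbonyl carbon. In an assay on LtK cells with ATP-sensitive inward rectifier potassium channel 11 (Homo sapiens) as the target (on this read-out lower numbers stand for an effect already at smaller amounts and higher numbers for an effect only at larger amounts of compound), compound 3 `O=C(Nc1c(C(O)(C(F)(F)F)C(F)(F)F)ccc2ccccc12)c1cccc(Cl)c1` gives 98 nM, the lowest number of the three. Compound 1 `O=C(Nc1c(C(O)(C(F)(F)F)C(F)(F)F)ccc2ccccc12)C1CC1` gives 751 nM in this assay, and compound 2 `Cc1ccccc1C(=O)Nc1c(C(O)(C(F)(F)F)C(F)(F)F)ccc2ccccc12` gives 5550 nM. The step of a 7.7-fold lower number from compound 1 to compound 3 (0.88 log units; beyond the scatter) and the step of a 57-fold lower number from compound 2 to compound 3 (1.75 log units; beyond the scatter) both point to the 3-chlorophenyl group of compound 3 as the one that sets it apart, while a 7.4-fold higher number from compound 1 to compound 2 (0.87 log units; beyond the scatter) shows that an aromatic group alone does not lower the number.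

Compound 4 `O=C(Nc1c(C(O)(C(F)(F)F)C(F)(F)F)ccc2ccccc12)c1ccco1` carries furan-2-yl in place of 3-chlorophenyl on a carbonyl carbon. For the measured compounds named here, no measured step covers a five-membered aromatic ring with one hetero atom here, so the steps into compound 3 are the only guide. Since both aromatic and non-aromatic replacements of 3-chlorophenyl gave higher numbers in compound 1 and compound 2, compound 4 is expected to show a higher number than compound 3, estimated as a 6.1-fold higher number from compound 3 to compound 4 (0.79 log units; beyond the scatter). For compound 4 the estimate in this assay is 600 nM, with a range from 150 nM to 2500 nM.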

Compound 4, half-maximal effective concentration: 9 nM
Estimate against measurement, compound 4: 67-fold (1.82 log units) above; measured number outside the range, below it.
By their numbers in this assay, from the lowest: compound 4; then compound 3; then compound 1; then compound 2.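

In this assay, the step of an 11-fold lower number from compound 3 to compound 4 (1.04 log units; beyond the scatter) shows that the 3-chlorophenyl group does not mark the low end at this place on the carbonyl carbon: a five-membered aromatic ring with 1 hetero atom and no chlorine goes lower still. The steps of a 620-fold lower number from compound 2 to compound 4 (2.79 log units; beyond the scatter) and an 83-fold lower number from compound 1 to compound 4 (1.92 log units; beyond the scatter) widen the span seen at this one place well beyond what the three earlier groups showed, and they show that the kind of aromatic ring matters a great deal here. Nothing available on these compounds accounts for the low number of the furan-2-yl amide.

As far as these compounds go, it remains open whether the ring oxygen or the ring size drives the change, which a thiophen-2-yl or an unsubstituted phenyl group on the same carbonyl carbon could separate. From the compounds shown here alone, it is also open whether a methyl group on the furan ring would keep the number this low.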